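Replacing a Hydroxy Hydrogen on Compound 3

This account rests on a few compounds, and the source may have more. Where it says the series, first, only, none or still open, it means among the compounds named here.

In a physicochemical assay for acid dissociation, compound 1 (`NS(=O)(=O)c1ccc(SCCCO)c(Cl)c1`) gives 9.45 while compound 2 (`NS(=O)(=O)c1ccc(S(=O)(=O)CCCO)c([N+](=O)[O-])c1`) gives 8 and compound 3 (`NS(=O)(=O)c1ccc(S(=O)(=O)CCCO)s1`) gives 8.32 as its reading. Compound 3 therefore stands second highest of the three, and its gaps to both of the others lie beyond the scatter. Compound 4 (`COCC(=O)OCCCS(=O)(=O)c1ccc(S(N)(=O)=O)s1`) differs from compound 3 in one place ((methoxymethyl)carbonyl in place of hydrogen on an oxygen on a saturated carbon) with (methoxymethyl)carbonyl in place of hydrogen on an oxygen on a saturated carbon. Going by the values given here, no two measured compounds differ in a single place, so no measured step can guide the size. The change expected in this assay is none beyond the scatter, in either direction (a number 0.02 log units lower from compound 3 to compound 4 (within the scatter)). That expectation takes the reading of compound 3 (8.32) as its starting point. For compound 4 the estimated value is 8.3 (expected range 8 to 8.6).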

Compound 4, acid dissociation constant: 8.1
Compound 4: middle estimate off by 0.20 log units, on the high side; the range from low to high includes it.
By their numbers in this assay, from the lowest: compounds 2, 4 and 3 (each within the scatter of the next, the first and the last beyond it); then compound 1.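

In this assay, placing (methoxymethyl)carbonyl on the oxygen gives a number 0.22 log units lower from compound 3 to compound 4 (within the scatter) as the first step measured at a single place. At this oxygen on a saturated carbon, then, a hydrogen can give way to a group of 5 heavy atoms while the two readings remain indistinguishable within the usual spread of repeats. Nothing available offers an explanation for this reading. Going by these compounds, whether an acetyl group or a longer chain on the same oxygen would behave alike remains open. So does whether an amine in place of the hydroxy would do so, or the same replacement on the core of compound 2.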